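Cytotoxicity notes: benzamido for (phenylsulfonyl)amino on the core

The source may report more compounds than this note shows. Statements on the series, on what has been measured and on what is new or still open speak of the compounds shown alone.

Measured in an ADME assay on MT4 cells (Homo sapiens) for cytotoxicity, read by MTT assay, with a stated time of 4 days; on this read-out higher numbers stand for lower toxicity in this test and lower numbers for higher toxicity in this test:
compound 1 `Cc1ccc(-c2c(C)c(-c3ccc(C)c(C)c3)c(C(OC(C)(C)C)C(=O)O)c(C)c2NS(=O)(=O)c2ccccc2)cc1C` gives 11000 nM
compound 2 `Cc1ccc(-c2c(C)c(-c3ccc4c(c3)CCCO4)c(C(OC(C)(C)C)C(=O)O)c(C)c2NS(C)(=O)=O)cc1C` gives 28000 nM
compound 3 `Cc1ccc(-c2c(C)c(-c3ccc(Cl)c(F)c3)c(C(OC(C)(C)C)C(=O)O)c(C)c2NS(C)(=O)=O)cc1C` gives 22000 nM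

Compound 1 stands at the lowest of the three numbers in this assay. Its gap to compound 3 lies within the scatter, so no order is claimed between these two; the gap to compound 2 lies beyond the scatter. The only step shown between measured compounds, a 1.3-fold lower number from compound 2 to compound 3 (0.10 log units; within the scatter), concerns the aryl group on the core and lies within the scatter.

Compound 4 `Cc1ccc(-c2c(C)c(-c3ccc(C)c(C)c3)c(C(OC(C)(C)C)C(=O)O)c(C)c2NC(=O)c2ccccc2)cc1C` differs from compound 1 by benzoyl in place of phenylsulfonyl on a nitrogen on an aromatic ring. No measured pair in this series changes the group on that nitrogen, so nothing shown bears directly on this step; all three measured compounds keep a sulfonyl group there. With no step beyond the scatter anywhere in the series and no reference for this change, compound 4 is expected to give a number near that of compound 1. The step expected is a 1.2-fold higher number from compound 1 to compound 4 (0.07 log units; within the scatter), within the scatter. For compound 4 the estimate in this assay is 13000 nM, with a range from 5000 nM to 35000 nM.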

Compound 4, half-maximal cytotoxic concentration: 9100 nM
Beside the measured number, compound 4's estimate is 1.4-fold (0.15 log units) above it; low and high end bracket the measured number.
By their numbers in this assay, from the lowest: compounds 4, 1, 3 and 2 (each within the scatter of the next, the first and the last beyond it).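

In this assay, the first change shown on the nitrogen on an aromatic ring, benzoyl in place of phenylsulfonyl, gives a 1.2-fold lower number from compound 1 to compound 4 (0.08 log units; within the scatter). The sulfonyl group is therefore not required at this position to keep the number in this range, and the (phenylsulfonyl)amino and benzamido forms of the core of compound 1 are not told apart by this read-out. No supporting data are available to explain this result.

From the compounds shown here alone, it remains open whether a free amine on that nitrogen, a short acyl group such as acetyl, or a benzoyl ring carrying a carboxylic acid would stay in this range. Within the data shown here, it is also open whether benzamido behaves the same way with the other aryl groups on the core, such as the one in compound 3.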